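A few compounds are considered here, and "the series" means these few. Any claim that something is new, unique, unknown or untested is made for them only; others in the source may bear on it.

Three compounds that share a long acid-bearing side chain, an unsaturated hydroxyl-bearing linker and a benzene ring have been tested in an assay on CHO cells for displacement of a labelled ligand from prostaglandin E2 receptor EP2 subtype (Mus musculus), read by scintillation counting, with a stated time of 60 min; on this read-out higher numbers stand for weaker inhibition and lower numbers for stronger inhibition. Compound 1 `CCCc1cccc(C[C@H](O)/C=C/[C@H]2CCC(=S)N2CCCCCCC(=O)O)c1` carries a propyl group on that ring together with a different acid chain and core; in this assay compound 1 gives 6800 nM. Compound 3 `Cc1cccc(C[C@H](O)/C=C/[C@H]2CCC(=S)N2CCSCCCC(=O)O)c1` carries a methyl group on the ring and in this assay gives 1700 nM. Compound 2 `O=C(O)CCCSCCN1C(=O)SC[C@@H]1/C=C/[C@@H](O)Cc1ccccc1` has a bare ring. For compound 2 this assay records only a limit, > 10000 nM, which is not a number. Compound 2 thus sits at the weak edge of the data because the limit of > 10000 nM in this assay, at which 1 of the 3 values shown sits, is where its reading stands.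

Compound 4 `COCc1cccc(C[C@H](O)/C=C/[C@H]2CSC(=O)N2CCSCCCC(=O)O)c1` has not been measured. Within the data shown here, it keeps the core and acid chain of compound 2, the only change being (methoxymethyl in place of hydrogen on an aromatic carbon). Among the measured compounds shown here, no measured pair differs in exactly this way, so the size of the step is not known. Compound 3 differs from compound 2 in both core and ring group, so it gives only a loose hint that a group on the ring can bring a measurable value. Compound 4 is expected to give 3500 nM, with a range from 900 nM to 12000 nM. The expected step is an at least 2.8-fold lower number from compound 2 to compound 4 (0.45 log units; beyond the scatter), toward stronger binding, though a reading that again ends at a limit remains possible.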

Compound 4, inhibition constant: > 10000 nM
Compound 4: only a limit was reported; the forecaster's own chance of this, stated with the estimate: 30%; at least 2.8-fold (0.45 log units) between middle value and limit.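

In this assay, among these compounds, compound 2 and compound 4 each end at a limit rather than a number, so no step between them can be read: the limit of > 10000 nM in this assay, at which 2 of the 4 values shown sit.

The compounds shown leave open whether methoxymethyl in place of hydrogen on an aromatic carbon changes binding at all, and if so, in which direction.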